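This account rests on a few compounds, and the source may have more. Where it says the series, first, only, none or still open, it means among the compounds named here.

For the measured compounds named here, in a physicochemical assay for solubility, using the shake flask method, in phosphate buffer, with a stated time of 24 h, at pH 7.4 (a lower number here means a less soluble compound, a higher number a more soluble compound), compound 1 `CC(Sc1nc2c(cnn2C)c(=O)n1-c1ccccc1)c1cccnc1` gives 209000 nM, and compound 2 `CC(Sc1nc2c(cnn2C)c(=O)n1-c1ccccc1)c1cccc(O)c1` gives 21000 nM, the lower of the two numbers measured so far. The next compound to consider is compound 3 `Cn1ncc2c(=O)n(-c3ccccc3)c(SCc3cccc(F)c3)nc21`, which has not yet been measured. It keeps the shared core but carries 3-fluorobenzyl on the sulfur: a group of 8 heavy atoms (7 carbon, 1 fluorine; one six-membered aromatic ring of carbon only) in place of a group of 9 heavy atoms (8 carbon, 1 oxygen; one six-membered aromatic ring of carbon only), on a sulfur. Going by the values given here, only one measured step bears on this change: a 10-fold lower number from compound 1 to compound 2 (1.00 log units; beyond the scatter). That step lies beyond the usual scatter and comes from placing 3-hydroxyphenyl where pyridin-3-yl stood, within the same group on the sulfur. Among the compounds with values here, it shows that changing this group alone can clearly move the number, but it is only an indirect guide, since no measured compound carries 3-fluorobenzyl. A modest move to a lower number in this assay is expected, though with little confidence in its size or direction. The expected change is a 2.6-fold lower number from compound 2 to compound 3 (0.42 log units; beyond the scatter). Compound 3 is estimated at 8000 nM, with an expected range of 2000 nM to 30000 nM.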

Compound 3, solubility: < 700 nM
Compound 3 gave a limit, no number; the forecaster's own chance of this, stated with the estimate: 10%; middle value at least 11-fold (1.05 log units) away from the limit.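

In this assay, for the compounds shown here, the group on the sulfur proves able to move the reading much further than the one earlier step showed: 3-fluorobenzyl gives an at least 30-fold lower number from compound 2 to compound 3 (1.47 log units; beyond the scatter), and in place of 1-(pyridin-3-yl)ethyl it gives an at least 290-fold lower number from compound 1 to compound 3 (2.47 log units; beyond the scatter). Both of these steps are large, whereas a 10-fold lower number from compound 1 to compound 2 (1.00 log units; beyond the scatter) was modest, and 3-fluorobenzyl counts 0 hydrogen-bond donors and 0 hydrogen-bond acceptors, while the group it replaces in compound 2 counts 1 of each. The reading for compound 3 is a limit and not a number, which leaves the full size of both steps unknown: the limit of < 700 nM in this assay, at which 1 of the 3 values shown sits.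

The compounds shown leave open whether the drop goes with fluorine replacing the hydroxyl on the ring or with the benzyl link replacing the ethyl one, as both changes arrive together between compound 2 and compound 3. Going by these compounds, a 3-hydroxybenzyl group on the sulfur would separate those two changes, and how an amine or a carboxylic acid on that ring would read in this assay also remains open.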